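The source may report more compounds than this note shows. Statements on the series, on what has been measured and on what is new or still open speak of the compounds shown alone.

Measured so far in a functional assay on the whole organism with Rattus norvegicus as the target; a higher number here means that more compound is needed for the effect, a lower number that less compound is needed:
- compound 1 `CCOC(=O)C(=O)Nc1nc(-c2cccc(OC)c2)cs1` — compound 1 gives about 20 mg/kg
- compound 2 `CCOC(=O)C(=O)Nc1nc(-c2ccc(OC)cc2)cs1` — compound 2 gives about 10 mg/kg
- compound 3 `CCOC(=O)C(=O)Nc1nc(-c2cc(OC)cc(OC)c2)cs1` — compound 3 gives about 10 mg/kg

Compounds 1 and 3 share a core; the change from compound 1 to compound 3 is methoxy in place of hydrogen on an aromatic carbon and gave a 2.0-fold lower number from compound 1 to compound 3 (0.30 log units; within the scatter). Compound 2 is built from the same atoms as compound 1 joined differently; the difference between the two cores is not broken down here. In this assay compound 2 stands level with compound 3 at the digits given, and the gap to compound 1 is within the scatter, so no order among the three can be read from these numbers.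

Compound 4 `CCOC(=O)C(=O)Nc1nc(-c2ccc(OC)cc2OC)cs1` is not yet measured. From compound 2 it differs by methoxy in place of hydrogen on an aromatic carbon. This is the same kind of change as from compound 1 to compound 3, with one difference around the place: in compound 4 the entering group sits ortho to a large group, whereas in compound 3 it sits meta to a large group; in both it is meta to a methoxy group. Within the data shown here, the only measured instance of the change, a 2.0-fold lower number from compound 1 to compound 3 (0.30 log units; within the scatter), lies within the scatter, so the step from compound 2 to compound 4 is expected to be small as well, estimated at a 1.3-fold lower number from compound 2 to compound 4 (0.10 log units; within the scatter). Among the measured compounds shown here, on that basis compound 4 is expected to give about 8 mg/kg in this assay, with a likely range from 4 mg/kg to 20 mg/kg; the change of place relative to the large group has no measured precedent here, which widens the range.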

Compound 4, dose for half-maximal effect: > 30 mg/kg
Compound 4 was reported as a limit (the forecaster's own chance of this, stated with the estimate: 5%); middle value at least 3.7-fold (0.57 log units) from the limit.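

In this assay, methoxy in place of hydrogen on an aromatic carbon gives an at least 3.0-fold higher number from compound 2 to compound 4 (0.47 log units; beyond the scatter), so the change does not carry over unchanged from the core of compound 1 to the core of compound 2: the same change on two cores in this assay, a 2.0-fold lower number (0.30 log units; within the scatter) from compound 1 to compound 3 and an at least 3.0-fold higher number (0.47 log units; beyond the scatter) from compound 2 to compound 4, at least 6.0-fold (0.77 log units) apart, beyond the scatter of two such steps

Compound 4 is reported as > 30 mg/kg, which is a limit of the assay and not a number, so only the direction and a minimum size of the step can be read: the limit of > 30 mg/kg in this assay, at which 1 of the 4 values shown sits.

With one instance on each core, the data do not show whether the gap between the two steps goes with the core or with the place of the entering group, which in compound 4 is ortho to a large group, and they do not give a general rule for this change across the series.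

As far as these compounds go, it remains open whether fluorine, chlorine or methyl entering ortho to a large group on the core of compound 2 would give a step in the same direction as methoxy in this assay. Also open, from the compounds shown here alone, is how these aryl patterns would read with a carboxylic acid or an amide in place of the ethyl ester.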